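The source may report more compounds than this note shows. Statements on the series, on what has been measured and on what is new or still open speak of the compounds shown alone.

Measured so far:
- Compound 1 `CC1=CC(=O)[C@@H]2[C@@]3(C)CCCC(C)(C)[C@@H]3[C@@H](O)C[C@]2(C)c2c1ccc(C)c2O`: 4700 nM
- Compound 2 `C=C1/C=C\[C@@H]2[C@@]3(C)CCCC(C)(C)[C@@H]3[C@H](O)C[C@@]2(C)O[C@@H]2C=C(C)C(=O)C[C@H]12`: 3900 nM

In a functional assay on A549 cells (Homo sapiens) for cytotoxicity (on this read-out higher numbers stand for lower toxicity in this test and lower numbers for higher toxicity in this test), compound 1 gives 4700 nM and compound 2 gives 3900 nM. Among the compounds with values here, these two numbers lie within the usual scatter of repeated measurements, so compound 1 cannot be separated from the only other compound measured here.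

The next compound to be tested is compound 3 `COc1c(C)ccc2c1[C@@]1(C)C[C@H](O)[C@H]3C(C)(C)CCC[C@]3(C)[C@H]1C(=O)C=C2C`. It keeps the core of compound 1 and makes one change, with methyl in place of hydrogen on an oxygen on an aromatic ring, so that hydroxy becomes methoxy: methyl in place of hydrogen on an oxygen on an aromatic ring.

Within the data shown here, no measured pair carries this change, so the data offer no direct precedent for its size or direction. The starting point is therefore compound 1 at 4700 nM, and no step beyond the scatter is expected in this assay, although the uncertainty is wide. The expected change is a 1.2-fold higher number from compound 1 to compound 3 (0.07 log units; within the scatter). For compound 3 the estimated value is 5500 nM, with an expected range from 2000 nM to 15000 nM.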

Compound 3, concentration lethal to 50% of the cells: > 100000 nM
Compound 3 gave a limit, no number; the forecaster's own chance of this, stated with the estimate: 10%; middle value at least 18-fold (1.25 log units) from the limit.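

In this assay, compound 3 gives > 100000 nM, which is a limit of the assay and not a number. Within the data shown here, putting methyl in place of hydrogen on this oxygen on an aromatic ring, so that hydroxy becomes methoxy, gives an at least 21-fold higher number from compound 1 to compound 3 (1.32 log units; beyond the scatter), the first step in these data that can be read at this place, and it shows that one added carbon here is enough to move the result far beyond the scatter, towards lower toxicity in this test. The step has a floor but no known upper end, and the real distance between the two compounds cannot be read: the limit of > 100000 nM in this assay, at which 1 of the 3 values shown sits.

The compounds shown do not separate two readings of this step: the loss of the hydrogen on the oxygen may be what counts, or the presence of the methyl may be. A longer chain on the same oxygen, such as ethyl, or an acetyl group there, or an amine in place of the hydroxy, would help to tell these apart, and why the change has this effect stays open.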